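The source may report more compounds than this note shows. Statements on the series, on what has been measured and on what is new or still open speak of the compounds shown alone.

Compound 3 `Clc1cccc([C@@H]2C[C@@H]3Cc4ccc5ccccc5c4N2O3)c1` is one of three compounds that share a core and differ only in the substituted phenyl ring on a saturated ring carbon. In an ADME assay on Vero cells (Chlorocebus sabaeus) for cytotoxicity, read by MTT assay, with a stated time of 72 h (on this read-out lower numbers stand for higher toxicity in this test and higher numbers for lower toxicity in this test), compound 3 gives > 300000 nM, which is a limit of the test rather than a measured number. Compound 1 `Fc1ccc([C@@H]2C[C@@H]3Cc4ccc5ccccc5c4N2O3)cc1` gives > 300000 nM in this assay, again a limit. Compound 2 `Brc1ccc([C@@H]2C[C@@H]3Cc4ccc5ccccc5c4N2O3)cc1` gives > 250000 nM in this assay, also a limit. Because every value sits at a limit, the steps a step that the two limits leave unreadable from compound 1 to compound 2, a step that the two limits leave unreadable from compound 1 to compound 3 and a step that the two limits leave unreadable from compound 2 to compound 3 cannot be given a size: the limit of > 250000 nM in this assay, at which 1 of the 3 values shown sits, and the limit of > 300000 nM in this assay, at which 2 of the 3 values shown sit, mark where all the values stop. Compound 4 `COc1cccc([C@@H]2C[C@@H]3Cc4ccc5ccccc5c4N2O3)c1` is the next step, a change of methoxy in place of chloro on an aromatic carbon. Among the compounds with values here, none of the measured steps speaks to this change, since each of them connects two limits and shows neither a direction nor a size. Within the data shown here, the expectation for compound 4 therefore rests only on the fact that every compound so far stays at the top of the range, so the step of a number no higher from compound 3 to compound 4 (the limit leaves the size open) is expected to be none beyond the scatter. The value for compound 4 in this assay is estimated at 300000 nM, within 60000 nM to 300000 nM, most probably reported again as a limit.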

Compound 4, half-maximal cytotoxic concentration: > 300000 nM
Compound 4: only a limit was reported; the forecaster's own chance of this, stated with the estimate: 80%; the middle value sits exactly at the limit.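

In this assay compound 4 gives > 300000 nM, which is a limit and not a measured number. The steps to compound 4 from compound 1, compound 2 and compound 3 therefore cannot be read. The four compounds leave open the concentration at which any of them would become toxic to these cells, and how they rank against one another.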